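This account rests on a few compounds, and the source may have more. Where it says the series, first, only, none or still open, it means among the compounds named here.

Measured so far:
Compound 1 `O=[N+]([O-])c1ccc(N/C(=N\O)c2ccccc2Br)c2nonc12` — in an assay on isolated protein for inhibition of Indoleamine 2,3-dioxygenase 1 (Homo sapiens), read by HPLC, with a stated time of 1.5 h (a lower number here means a stronger inhibitor, a higher number a weaker inhibitor), compound 1 gives 64 nM.
Compound 2 `O=[N+]([O-])c1ccc(N/C(=N\O)c2cccc(F)c2)c2nonc12` — in this assay compound 2 gives 84 nM.

Compound 1 has the lower of these two numbers, but only narrowly: the change from compound 1 to compound 2 gave a 1.3-fold higher number from compound 1 to compound 2 (0.12 log units; within the scatter), so the two cannot be told apart with confidence. Compound 3 `O=[N+]([O-])c1ccc(N/C(=N\O)c2ccc(F)cc2)c2nonc12` differs from compound 1 in one place: 4-fluorophenyl in place of 2-bromophenyl on a carbon with a double bond to nitrogen. Among the measured compounds shown here, the one measured step that bears on exchanging this ring, from compound 1 to compound 2, stayed within the scatter, so no step beyond the scatter is expected here either. Compound 3 is estimated at 90 nM, with a range from 40 nM to 250 nM. That would be an expected step of a 1.4-fold higher number from compound 1 to compound 3 (0.15 log units; within the scatter), within the scatter.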

Compound 3, half-maximal inhibitory concentration: 60 nM
Compound 3: middle estimate off by 1.5-fold (0.18 log units), on the high side, and the stated range covers the measured number.
By their numbers in this assay, from the lowest: compounds 3, 1 and 2 (each within the scatter of the next).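

In this assay, exchanging the ring gave a 1.1-fold lower number from compound 1 to compound 3 (0.03 log units; within the scatter), and moving the fluorine gave a 1.4-fold lower number from compound 2 to compound 3 (0.15 log units; within the scatter). On the carbon with a double bond to nitrogen, 2-bromophenyl, 3-fluorophenyl and 4-fluorophenyl have now all been compared, and none of the steps among compounds 1, 2 and 3 goes beyond the scatter, so where the halogen sits on this ring makes no readable difference among these three. No measurement at hand explains this.

Still open, on these data alone, is whether a phenyl ring carrying an amine or a carboxylic acid, or a saturated cyclohexyl ring, would stay this close.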